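This account rests on a few compounds, and the source may have more. Where it says the series, first, only, none or still open, it means among the compounds named here.

Compound 1, `C=CC(=O)Nc1ccc(Cn2nc(-c3ccc(Oc4ccccc4)cc3)cc2C(=O)OCC)cc1`, is the starting point; in a functional assay on Z-138 cells (Homo sapiens) for inhibition, read by luminescence and CellTiter-Glo, with a stated time of 72 h (on this read-out higher numbers stand for weaker inhibition and lower numbers for stronger inhibition), compound 1 gives 12500 nM. Compound 2, `C=CC(=O)Nc1cccc(Cn2nc(-c3ccc(Oc4ccccc4)cc3)cc2C(=O)OCC)c1`, has the same atoms joined differently, the change being (3-((vinylcarbonyl)amino)phenyl in place of 4-((vinylcarbonyl)amino)phenyl on a saturated chain carbon bound to an aromatic nitrogen); in this assay compound 2 gives 7800 nM, a step of a 1.6-fold lower number from compound 1 to compound 2 (0.20 log units; within the scatter). Compound 3, `C=CC(=O)Nc1ccc(Cn2nc(-c3ccc(Oc4ccccc4)cc3)cc2CO)cc1`, carries the change (hydroxymethyl in place of ethoxycarbonyl on an aromatic carbon), and compound 3 gives 6800 nM, a step of a 1.8-fold lower number from compound 1 to compound 3 (0.26 log units; within the scatter). Compound 4, `C=CC(=O)Nc1cccc(Cn2nc(-c3ccc(Oc4ccccc4)cc3)cc2CO)c1`, is not yet measured; it differs from compound 2 by hydroxymethyl in place of ethoxycarbonyl on an aromatic carbon, the same change as that from compound 1 to compound 3, on the core of compound 2. The step from compound 2 to compound 4 is expected to be a 1.8-fold lower number from compound 2 to compound 4 (0.26 log units; within the scatter), resting on compound 1 and compound 3 because of a 1.8-fold lower number from compound 1 to compound 3 (0.26 log units; within the scatter). Compound 4 is therefore expected at 4300 nM, between 2000 nM and 9000 nM.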

Compound 4, half-maximal inhibitory concentration: 6000 nM
The estimate for compound 4 lay 1.4-fold (0.14 log units) below the measured number; the range from low to high includes it.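

In this assay putting hydroxymethyl in place of ethoxycarbonyl gives a 1.3-fold lower number from compound 2 to compound 4 (0.11 log units; within the scatter) and so leaves no difference that can be told from repeat scatter. The earlier step on the other core looks the same: the same change on two cores in this assay, a 1.8-fold lower number (0.26 log units; within the scatter) from compound 1 to compound 3 and a 1.3-fold lower number (0.11 log units; within the scatter) from compound 2 to compound 4, 1.4-fold (0.15 log units) apart, within the scatter of two such steps. The change therefore behaves alike on these two cores, but since neither step exceeds the scatter, this does not show that it strengthens inhibition on either core, or that the agreement would hold on any further core.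

The compounds shown leave open whether another group at this place, such as a carboxylic acid, an amine or a longer chain, would give a step beyond the scatter.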